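Thiosemicarbazones on a shared core: aryl swap to thiophene

The source may report more compounds than this note shows. Statements on the series, on what has been measured and on what is new or still open speak of the compounds shown alone.

Measured in a functional assay on MCF7 cells (Homo sapiens) for inhibition, read by sulforhodamine B assay, with a stated time of 48 h; on this read-out higher numbers stand for weaker inhibition of growth and lower numbers for stronger inhibition of growth:
compound 1 `COc1ccc(/C=N/NC(=S)NC(C)(C)[C@H]2CC=C(C)CC2)cc1` gives 37700 nM
compound 2 `CC1=CC[C@H](C(C)(C)NC(=S)N/N=C/c2ccc(O)cc2)CC1` gives only a limit, > 100000 nM
compound 3 `CC1=CC[C@H](C(C)(C)NC(=S)N/N=C/c2cccc(Cl)c2)CC1` gives 61000 nM

Compound 3 stands at the highest of the two numbers in this assay; its nearest neighbour is compound 1, with a 1.6-fold higher number from compound 1 to compound 3 (0.21 log units; within the scatter). The step of an at least 2.6-fold higher number from compound 1 to compound 2 (0.42 log units; beyond the scatter) is the only one beyond the scatter, and it runs against a limit (the limit of > 100000 nM in this assay, at which 1 of the 3 values shown sits). The step of an at least 1.6-fold lower number from compound 2 to compound 3 (0.21 log units; that floor lies within the scatter) has a floor within the scatter.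

Compound 4 `CC1=CC[C@H](C(C)(C)NC(=S)N/N=C/c2cccs2)CC1` differs from compound 3 by thiophen-2-yl in place of 3-chlorophenyl on a carbon with a double bond to nitrogen. Going by the values given here, no measured step exchanges a phenyl ring for thiophene; the one aryl-for-aryl step, from compound 1 to compound 3, stayed within the scatter. Compound 4 is therefore expected to lie near compound 3, with a 1.0-fold lower number from compound 3 to compound 4 (0.01 log units; within the scatter) expected. Compound 4 is estimated at 60000 nM, between 25000 nM and 150000 nM.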

Compound 4, concentration for total growth inhibition: 11500 nM
Beside the measured number, compound 4's estimate is 5.2-fold (0.72 log units) above it, outside the stated range (below it).
By their numbers in this assay, from the lowest: compound 4; then compounds 1 and 3 (each within the scatter of the next). At a limit, above all of these: compound 2.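

On the carbon with a double bond to nitrogen, an aryl-for-aryl exchange now gives steps beyond the scatter in this assay, with a 5.3-fold lower number from compound 3 to compound 4 (0.72 log units; beyond the scatter) and also a 3.3-fold lower number from compound 1 to compound 4 (0.52 log units; beyond the scatter). Thiophen-2-yl is thus the first group here with a lower number than both phenyl compounds with measured numbers, whereas compound 1 and compound 3 stayed within the scatter of each other. The step of an at least 8.6-fold lower number from compound 2 to compound 4 (0.93 log units; beyond the scatter) gives only a floor, since compound 2 stands at a limit: the limit of > 100000 nM in this assay, at which 1 of the 4 values shown sits.

Whether the sulfur, the five-membered ring or the loss of the phenyl ring accounts for the step remains open. Furan-2-yl or pyridin-2-yl at this place would help to separate these.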